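The source may report more compounds than this note shows. Statements on the series, on what has been measured and on what is new or still open speak of the compounds shown alone.

Measured so far in an ADME assay on CCRF-CEM cells (Homo sapiens) for antiproliferative activity, with a stated time of 48 h; on this read-out higher numbers stand for weaker inhibition and lower numbers for stronger inhibition

Compound 1 `C=C(Br)C(=O)Nc1ccc(/C=C/C(=O)c2ccccc2)cc1` gives 4000 nM
Compound 2 `Nc1ccc(/C=C/C(=O)c2ccccc2)cc1` gives 34000 nM
Compound 3 `COc1cccc(C(=O)/C=C/c2ccc(N)cc2)c1` gives 26000 nM

Compound 2 lies at the high end of these three numbers, and its gap to compound 3 is within the scatter. Of the two measured steps, an 8.5-fold higher number from compound 1 to compound 2 (0.93 log units; beyond the scatter) concerns hydrogen in place of (1-bromoethenyl)carbonyl on a nitrogen on an aromatic ring, a change at another place, so it offers little guidance here. The closer guide is a 1.3-fold lower number from compound 2 to compound 3 (0.12 log units; within the scatter), with methoxy in place of hydrogen on an aromatic carbon, and that step stays within the scatter. Compound 4 `CCOc1ccc(C(=O)/C=C/c2ccc(N)cc2)cc1` is reached from compound 2 by ethoxy in place of hydrogen on an aromatic carbon, para to a large group. Resting on that single methoxy step, no change beyond the scatter is expected in this assay. The estimated step is a 1.4-fold lower number from compound 2 to compound 4 (0.15 log units; within the scatter) and no larger in expectation. For compound 4 the estimated value is 24000 nM, with an expected range from 10000 nM to 55000 nM.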

Compound 4, half-maximal inhibitory concentration: 15000 nM
Compound 4: the middle estimate sits 1.6-fold (0.20 log units) above what was measured; low and high end bracket the measured number.
By their numbers in this assay, from the lowest: compound 1; then compounds 4, 3 and 2 (each within the scatter of the next, the first and the last beyond it).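

In this assay, ethoxy in place of hydrogen on an aromatic carbon, para to a large group, gives a 2.3-fold lower number from compound 2 to compound 4 (0.36 log units; beyond the scatter). The earlier methoxy step, a 1.3-fold lower number from compound 2 to compound 3 (0.12 log units; within the scatter), stayed within the scatter, so this is the first change on that aromatic ring among the compounds shown to go beyond it, though the step is only modest. Nothing measured here accounts for this step.

The compounds shown leave open whether the step follows from the ethoxy group itself or from its place on the ring, and whether a longer chain such as butoxy, or a hydroxyl or an amine on the same carbon, would move the number further. They also leave open whether the (1-bromoethenyl)carbonyl group on the nitrogen would add to this step if combined with the ethoxy group.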